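Extending the oxime ether oxygen of compound 1

A few compounds are considered here, and "the series" means these few. Any claim that something is new, unique, unknown or untested is made for them only; others in the source may bear on it.

Compound 1 `C/C(=N\OC(C)C)c1ccc(Sc2cc(F)cc(C3CCOCC3)c2)cc1` gives 920 nM in a functional assay (blood) for inhibition, with Homo sapiens as the target (on this read-out lower numbers stand for stronger inhibition and higher numbers for weaker inhibition), the highest of the three numbers measured: compound 2 `CCOC(=O)/C(=N\O)c1ccc(Sc2cc(F)cc(C3CCOCC3)c2)cc1` gives 170 nM and compound 3 `CS/C(=N\O)c1ccc(Sc2cc(F)cc(C3CCOCC3)c2)cc1` gives 190 nM. Compound 4 `COC(=O)C(C)(C)CO/N=C(\C)c1ccc(Sc2cc(F)cc(C3CCOCC3)c2)cc1` differs from compound 1 at the oxygen whose other neighbour is the double-bonded nitrogen: 2-(methoxycarbonyl)-2-methylpropyl in place of isopropyl on an oxygen. For the measured compounds named here, no measured step touches that oxygen; the steps of a 5.4-fold lower number from compound 1 to compound 2 (0.73 log units; beyond the scatter) and a 4.8-fold lower number from compound 1 to compound 3 (0.69 log units; beyond the scatter) both concern the carbon with the double bond to nitrogen, while a 1.1-fold higher number from compound 2 to compound 3 (0.05 log units; within the scatter) stays within the scatter. Going by the values given here, with no direct precedent, the change is expected to leave compound 4 close to compound 1, a step of a 1.2-fold lower number from compound 1 to compound 4 (0.06 log units; within the scatter) being the estimate. Compound 4 is therefore expected to give 800 nM, within 300 nM to 2500 nM.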

Compound 4, half-maximal inhibitory concentration: 420 nM
Beside the measured number, compound 4's estimate is 1.9-fold (0.28 log units) above it; measured number inside the range.
By their numbers in this assay, from the lowest: compounds 2 and 3 (each within the scatter of the next); then compound 4; then compound 1.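

At the oxygen whose other neighbour is the double-bonded nitrogen, a larger group is accepted in this assay: 2-(methoxycarbonyl)-2-methylpropyl in place of isopropyl gives a 2.2-fold lower number from compound 1 to compound 4 (0.34 log units; beyond the scatter), a modest step towards stronger inhibition. It is the only step shown at this oxygen, and it shows that the number here can move beyond the scatter. Nothing shown explains this step.

From the compounds shown here alone, whether the ester or the chain carries the step stays open. A carboxylic acid or an amine at the end of the chain, or a plain alkyl chain of similar length, would bear on that.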